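Swapping pyridin-4-yl for 1,3-thiazol-2-yl on the amide

The source may hold more compounds than are shown below. What is called first, only, known or untested is meant among the compounds shown, and "the series" means these compounds.

Measured compounds:
- Compound 1 `COc1ccc2nc(C)cc(OCC(=O)Nc3cc(C)c(F)c(C)c3)c2c1`: in a toxicity assay on HepG2 cells (Homo sapiens) for inhibition, read by CellTiter-Glo, with a stated time of 48 h (a higher number here means a weaker inhibitor, a lower number a stronger inhibitor), compound 1 gives > 100000 nM, which is a limit of the assay.
- Compound 2 `COc1ccc2nc(C)cc(OCC(=O)Nc3ccncc3)c2c1`: in this assay compound 2 gives > 100000 nM, likewise a limit.

Compound 2 therefore stands at the top of the measured range, with no exact number, and its only comparator sits at the same limit. The step that the two limits leave unreadable from compound 1 to compound 2 cannot be sized, a situation summarised by the limit of > 100000 nM in this assay, at which 2 of the 2 values shown sit.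

Compound 3 `COc1ccc2nc(C)cc(OCC(=O)Nc3nccs3)c2c1` differs from compound 2 by 1,3-thiazol-2-yl in place of pyridin-4-yl on an amide-type nitrogen. For the measured compounds named here, the one measured step on this nitrogen exchanged one aryl group for another without either compound leaving the limit, so it offers no readable size at all. Nothing shown suggests that this further exchange should move the value within the measured range, and the expectation for compound 3 is that it likely remains at a limit, meaning a step that the limit leaves unreadable from compound 2 to compound 3. For compound 3 the estimated value in this assay is 150000 nM, within 40000 nM to 500000 nM.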

Compound 3, half-maximal inhibitory concentration: > 100000 nM
Compound 3: no number, only a limit (the forecaster's own chance of this, stated with the estimate: 80%); the middle value lies beyond the limit too.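

In this assay compound 3 gives > 100000 nM, which is a limit of the assay and not a number. The steps among compound 1, compound 2 and compound 3 therefore cannot be read: the limit of > 100000 nM in this assay, at which 3 of the 3 values shown sit. The compounds shown leave open how far beyond this limit each one lies, and whether any group on the amide nitrogen would give a measurable value.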